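This account rests on a few compounds, and the source may have more. Where it says the series, first, only, none or still open, it means among the compounds named here.

In an ADME assay on BHK cells (Mesocricetus auratus) for cytotoxicity, read by MTT assay, with a stated time of 96 h (on this read-out higher numbers stand for lower toxicity in this test and lower numbers for higher toxicity in this test), compound 1 `O=[N+]([O-])c1ccc(-c2nc3cc(C(F)(F)F)ccc3n2C2CCCCC2)cc1` gives > 100000 nM, which is a limit of the assay and not a number. Among the compounds with values here, compound 2 `Cn1c(-c2ccc(N)cc2)nc2cc(C(F)(F)F)ccc21` gives 85000 nM, so it holds the only true number so far. Compound 3 `Nc1ccc(-c2nc3cc(C(F)(F)F)ccc3n2C2CCCCC2)cc1` has cyclohexyl in place of methyl on an aromatic nitrogen. Within the data shown here, no pair of measured compounds differs at one place alone, so the data offer no direct guide to this change in this assay. The expected change, a 1.4-fold lower number from compound 2 to compound 3 (0.15 log units; within the scatter), is slight, toward a lower number and within the usual scatter. For compound 3 the estimated value is 60000 nM, with an expected range of 20000 nM to 100000 nM.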

Compound 3, half-maximal cytotoxic concentration: > 100000 nM
Compound 3: no number, only a limit (the forecaster's own chance of this, stated with the estimate: 35%); middle value at least 1.6-fold (0.22 log units) away from the limit.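

In this assay, cyclohexyl in place of methyl on the aromatic nitrogen gives an at least 1.1-fold higher number from compound 2 to compound 3 (0.07 log units; that floor lies within the scatter), so the lower number expected for this change did not appear. From the compounds shown here alone, compound 3 has a limit rather than a number, so the true size of this step remains unknown, and the step from compound 1 to compound 3 cannot be read. The top of the measurable range restricts what this series can show: the limit of > 100000 nM in this assay, at which 2 of the 3 values shown sit.

Going by these compounds, it remains open how an ethyl group or a longer chain would behave on this nitrogen. A carboxylic acid in place of the amino group is equally untested among the compounds shown.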